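The source may hold more compounds than are shown below. What is called first, only, known or untested is meant among the compounds shown, and "the series" means these compounds.

Measured in a functional assay on SW480 cells (Homo sapiens) for antiproliferative activity, read by MTT assay, with a stated time of 48 h; on this read-out lower numbers stand for stronger inhibition and higher numbers for weaker inhibition:
- Compound 1 `CCC(CCO)n1cnc2c(Cl)nc(F)nc21`: 19800 nM
- Compound 2 `CCC(CCO)n1cnc2c(Cl)ncnc21`: > 50000 nM, a limit of the assay
- Compound 3 `CCCCCCC(CCO)n1cnc2c(N)ncnc21`: > 50000 nM, a limit of the assay

Compound 1, at 19800 nM, is the only one of the three with an actual number.

The other two readings are limits and give no exact position.

The next compound to be tested is compound 4 `CCCCCCCC(CCO)n1cnc2c(Cl)nc(F)nc21`. It keeps the core of compound 1 and differs from it in one place: pentyl in place of hydrogen on a saturated chain carbon, three bonds along the chain from an aromatic nitrogen. In words, this is pentyl in place of hydrogen on a saturated chain carbon, three bonds along the chain from an aromatic nitrogen, which turns ethyl into heptyl.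

Among the measured compounds shown here, the one measured step is an at least 2.5-fold higher number from compound 1 to compound 2 (0.40 log units; beyond the scatter), with hydrogen in place of fluoro on an aromatic carbon. That step lies elsewhere on the molecule and does not touch the chain, so it gives no direct measure of this change. Compound 4 retains the fluoro, so the loss seen in that step is not expected to recur. Any guide to the chain change is therefore weak, and only a modest shift toward lower numbers in this assay is expected, with a wide margin either way from compound 1 at 19800 nM.

The expected step is a 2.2-fold lower number from compound 1 to compound 4 (0.34 log units; beyond the scatter).

For compound 4 the estimated value is 9000 nM, with an expected range from 2500 nM to 35000 nM.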

Compound 4, half-maximal inhibitory concentration: 26100 nM
For compound 4 the middle estimate is 2.9-fold (0.46 log units) below the measured one; the measured number falls inside the stated range.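

In this assay, replacing hydrogen with pentyl at this place, on a saturated chain carbon three bonds along the chain from an aromatic nitrogen, gives a 1.3-fold higher number from compound 1 to compound 4 (0.12 log units; within the scatter), so the two compounds cannot be told apart. Among the compounds shown here, this is the first reading of this position: the only earlier step concerned fluoro on an aromatic carbon and said nothing about the chain. With the fluoro and the chloro of compound 1 kept, the change from ethyl to heptyl leaves a measured number in place, and the added five carbons bring no change beyond the scatter in this assay.

From the compounds shown here alone, it remains open what a group other than a plain chain, such as a phenyl ring or a terminal amine, would do at this carbon, and whether a chain longer than heptyl would give the same reading. Compound 3 is a limit of the assay and not a number, and it differs from compound 4 in more than one place, so it adds nothing on this chain change: the limit of > 50000 nM in this assay, at which 2 of the 4 values shown sit.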